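A few compounds are considered here, and "the series" means these few. Any claim that something is new, unique, unknown or untested is made for them only; others in the source may bear on it.

Compound 1: `CCCCc1ccc(CNC(=O)Nc2ccccc2)c(=O)n1Cc1ccc(-c2ccccc2-c2nn[nH]n2)cc1` — 30 nM
Compound 2: `CCCCc1ccc(CN(Cc2ccccc2)S(=O)(=O)c2ccc(C)cc2)c(=O)n1Cc1ccc(-c2ccccc2-c2nn[nH]n2)cc1` — 60 nM

Of the compounds shown here, two have been measured in a functional assay (aorta) for antagonist activity, with Oryctolagus cuniculus as the target; a higher number here means a weaker inhibitor, a lower number a stronger inhibitor. Compound 1 gives 30 nM. Compound 2 gives 60 nM. The two numbers lie within the usual scatter of each other, so on these data compound 2 cannot be told apart from compound 1; neither stands out as the stronger or weaker inhibitor.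

Compound 3, `CCCCc1ccc(CN(Cc2ccccc2)S(C)(=O)=O)c(=O)n1Cc1ccc(-c2ccccc2-c2nn[nH]n2)cc1`, has not yet been measured. It differs from compound 2 in one place: methyl in place of 4-methylphenyl on a sulfonyl sulfur. The shared core and the sulfonamide itself are untouched; only the group on the sulfonyl sulfur changes, from (4-methylphenyl)sulfonyl to methylsulfonyl.

Within the data shown here, no measured pair in this set shows what such a change does, so the expectation rests on the change alone. Shrinking the group on the sulfonyl sulfur from 4-methylphenyl to methyl is expected to push the number upward, toward a weaker inhibitor, by a modest amount, so that the estimated step of a 2.5-fold higher number from compound 2 to compound 3 (0.40 log units; beyond the scatter) is small but likely beyond the scatter. For compound 3 the expected value in this assay is 150 nM, within an estimated range from 40 nM to 600 nM.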

Compound 3, half-maximal inhibitory concentration: 2 nM
Beside the measured number, compound 3's estimate is 75-fold (1.88 log units) above it, outside the stated range (below it).
By their numbers in this assay, from the lowest: compound 3; then compounds 1 and 2 (each within the scatter of the next).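

In this assay the group on the sulfonyl sulfur turns out to matter a great deal: methyl in place of 4-methylphenyl gives a 30-fold lower number from compound 2 to compound 3 (1.48 log units; beyond the scatter) and so, at this position, the aromatic ring of 7 heavy atoms is not needed for strong inhibition, and the single carbon of methyl goes with a far stronger inhibitor. The whole side group can also be read against the urea-type group of compound 1: benzyl(methylsulfonyl)amino in place of (phenylcarbamoyl)amino gives a 15-fold lower number from compound 1 to compound 3 (1.18 log units; beyond the scatter) and this makes compound 3 the strongest inhibitor of the three shown. Nothing available gives a reason for the size of these two steps.

With only methyl and 4-methylphenyl shown on the sulfonyl sulfur, it remains open whether ethyl, a longer chain or trifluoromethyl there would keep the number as low as in compound 3, or whether methyl is a sharp optimum. From the compounds shown here alone, it is also open how much the benzyl group on the sulfonamide nitrogen contributes, and whether a plain methyl or a hydrogen on that nitrogen would hold the gain.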